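Swapping a Chloro for a (4-Fluorophenyl)sulfanyl Group

A few compounds are considered here, and "the series" means these few. Any claim that something is new, unique, unknown or untested is made for them only; others in the source may bear on it.

Compound 1 `Clc1ncnc2c1ncn2Cc1ccccc1`: 7% in an assay on isolated protein for inhibition of Ca2+/calmodulin-dependent protein kinase II (CaM kinase II) (Rattus norvegicus), tested at 30 uM; on this read-out higher numbers stand for more inhibition at the one concentration tested (going by the name of the read-out) and lower numbers for less inhibition
Compound 2 `Fc1ccc(Cn2cnc3c(Cl)ncnc32)cc1`: 0% in this assay

Among the measured compounds shown here, compound 1 holds the highest of the two numbers in this assay, but the only other number, that of compound 2, lies a number 7 percentage points lower from compound 1 to compound 2 (within the scatter), so the two cannot be told apart. Compound 3 `Fc1ccc(Sc2ncnc3c2ncn3Cc2ccccc2)cc1` has not yet been measured. It differs from compound 1 in one place: (4-fluorophenyl)sulfanyl in place of chloro on an aromatic carbon. For the measured compounds named here, the single measured step, a fluoro in place of hydrogen on an aromatic carbon amounting to a number 7 percentage points lower from compound 1 to compound 2 (within the scatter), concerns a different position and a far smaller group, so it gives little guidance on the step from compound 1 to compound 3. Going by the values given here, with both measured compounds giving low numbers in this assay and no step of comparable kind to draw on, the change is expected to produce no step beyond the scatter, a number 3 percentage points higher from compound 1 to compound 3 (within the scatter). Compound 3 is therefore estimated at 10%, most likely falling between 0% and 35%, with the wide range reflecting how little the measured steps say about a replacement of this size.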

Compound 3, a percentage reported as inhibition, at one concentration (the size of the read-out at that concentration, not a potency): 0%
Compound 3: middle estimate off by 10 percentage points, on the high side; measured number inside the range.
By their numbers in this assay, from the lowest: compounds 2, 3 and 1 (each within the scatter of the next).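

In this assay, putting (4-fluorophenyl)sulfanyl in place of chloro on this aromatic carbon, next to the ring nitrogen, gives a number 7 percentage points lower from compound 1 to compound 3 (within the scatter). Among the compounds shown here, this is the first look at a large change at this position: the group brings 8 heavy atoms and a six-membered aromatic ring where a single chlorine stood, yet the result cannot be told apart from that of compound 1, so at this one concentration the larger group shows no gain in inhibition, and with numbers this close to zero, a loss would be hard to see. Nothing measured here offers a reason for this result.

Still open, from the compounds shown here alone, is whether another group on this carbon, such as an amine, a carboxylic acid or a longer chain, would move the number beyond the usual scatter of the measurement. Going by these compounds, it is also open whether the sulfur or the fluoro of the new group matters at all, which a comparison with phenylsulfanyl or methylsulfanyl on the core of compound 1 could begin to show.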